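The source may report more compounds than this note shows. Statements on the series, on what has been measured and on what is new or still open speak of the compounds shown alone.

Measured compounds:
- compound 1, `COc1ccc(OC)c(/C=C/C(=O)Nc2cc3c(Nc4ccc(F)c(Cl)c4)ncnc3cc2O[C@H]2CCOC2)c1`: 7300 nM
- compound 2, `COc1cc(/C=C/C(=O)Nc2cc3c(Nc4ccc(F)c(Cl)c4)ncnc3cc2O[C@H]2CCOC2)cc(OC)c1OC`: 4150 nM
- compound 3, `COc1cc(/C=C/C(=O)Nc2cc3c(Nc4ccc(F)c(Cl)c4)ncnc3cc2OC)cc(OC)c1`: "not active" (no number reported)

The three measured compounds were tested in a functional assay on A549 cells (Homo sapiens) for cytotoxicity, read by MTT assay, with a stated time of 72 h; a lower number here means a stronger inhibitor, a higher number a weaker inhibitor. Compound 1 gives 7300 nM. Compound 2 gives 4150 nM; the step of a 1.8-fold lower number from compound 1 to compound 2 (0.25 log units; within the scatter) is within the scatter, so the two stand together. Compound 3 stands apart: in this assay compound 3 was reported as not active, with no number attached, so there is no figure from which a step could be computed.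

Compound 4, `COc1cc(/C=C/C(=O)Nc2cc3c(Nc4ccc(F)c(Cl)c4)ncnc3cc2O[C@H]2CCOC2)cc(OC)c1`, is the unmeasured neighbour of compound 3. The change is oxolan-3-yl in place of methyl on an oxygen on an aromatic ring. Among the compounds with values here, no measured step tracks this exact change, since compound 3 has no number. What bears on it instead is that compounds 1 and 2 both carry the oxolan-3-yl group entering here and both give numbers in this assay, while compound 3, with methyl, did not. The expectation is therefore that compound 4 will yield a number in the region of compounds 1 and 2, though with a real chance that it too comes back without one. Compound 4 is estimated at 8000 nM, with a range from 3000 nM to 30000 nM.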

Compound 4, half-maximal inhibitory concentration: 10800 nM
Beside the measured number, compound 4's estimate is 1.4-fold (0.13 log units) below it; the range from low to high includes it.
By their numbers in this assay, from the lowest: compounds 2, 1 and 4 (each within the scatter of the next, the first and the last beyond it).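

With (oxolan-3-yl)oxy in place of methoxy, compound 4 returns a number in this assay, whereas compound 3 was reported as not active, so this change on the oxygen separates a reported number from none, although its size cannot be read as a step. With oxolan-3-yl held fixed, the loss of one methoxy gives a 2.6-fold higher number from compound 2 to compound 4 (0.42 log units; beyond the scatter), a modest step, while the change of aryl pattern gives a 1.5-fold higher number from compound 1 to compound 4 (0.17 log units; within the scatter), which leaves those two compounds together. No measured evidence accounts for either the missing number or these steps.

Going by these compounds, it remains open whether methoxy on this oxygen would also give no number with the 3,4,5-trimethoxyphenyl or 2,5-dimethoxyphenyl group. On these data alone, how a longer chain ending in an amine would read in place of oxolan-3-yl also remains open.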